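This account rests on a few compounds, and the source may have more. Where it says the series, first, only, none or still open, it means among the compounds named here.

Measured compounds in a functional assay on the whole organism (arterial blood) with Rattus norvegicus as the target; on this read-out higher numbers stand for an effect only at larger amounts of compound and lower numbers for an effect already at smaller amounts:

Compound 1, `Cc1nc2cnccc2n1CC1CCN(C(=O)N[C@H](C)c2ccccc2)CC1`, gives 0.017 mg/kg.
Compound 2, `Cc1nc2cnccc2n1CC1CCN(C(=O)N[C@@H](C)c2ccccc2)CC1`, gives 0.21 mg/kg.
Compound 3, `Cc1nc2cnccc2n1CC1CCN(C(=O)NC2(c3ccccc3)CC2)CC1`, gives 0.021 mg/kg.

All three share the same core and differ only in the group carried on the amide-type nitrogen at the end of the chain. Compound 3 stands second highest of the three numbers: its value sits within the scatter of compound 1, while compound 2 is further away with a 10-fold lower number from compound 2 to compound 3 (1.00 log units; beyond the scatter). Compounds 1 and 2 differ only in configuration as drawn, yet they show a 12-fold higher number from compound 1 to compound 2 (1.09 log units; beyond the scatter); because of the fact that compounds 1 and 2 differ only in the configuration as drawn, this step shows that this position is sensitive even to small changes. Replacing the 1-phenylethyl of compound 1 with the 1-phenylcyclopropyl of compound 3 gives a 1.2-fold higher number from compound 1 to compound 3 (0.09 log units; within the scatter), so that change costs nothing.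

Compound 4, `CCOC(=O)[C@H](CC(C)C)NC(=O)N1CCC(Cn2c(C)nc3cnccc32)CC1`, goes further: 1-(ethoxycarbonyl)-3-methylbutyl in place of 1-phenylcyclopropyl on an amide-type nitrogen. Among the measured compounds shown here, no measured step covers a change of this kind; the only related steps are the ones above, which show that the position tolerates a small change but reacts strongly to configuration. On that basis compound 4 is expected to show a loss, estimated as a 7.1-fold higher number from compound 3 to compound 4 (0.85 log units; beyond the scatter), giving an expected value of 0.15 mg/kg within a range of 0.02 mg/kg to 1.5 mg/kg.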

Compound 4, dose for 50% inhibition: 0.03 mg/kg
Compound 4: the middle estimate sits 5.0-fold (0.70 log units) above what was measured, and the stated range covers the measured number.
By their numbers in this assay, from the lowest: compounds 1, 3 and 4 (each within the scatter of the next); then compound 2.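

In this assay, among the compounds shown here, the group on the amide-type nitrogen does not need a phenyl ring, which all the earlier compounds carried: placing 1-(ethoxycarbonyl)-3-methylbutyl, with no ring at all, in place of 1-phenylcyclopropyl gives a 1.4-fold higher number from compound 3 to compound 4 (0.15 log units; within the scatter). The comparison with the 1-phenylethyl group reads the same way, with a 1.8-fold higher number from compound 1 to compound 4 (0.25 log units; within the scatter), while the other configuration of that group stands clearly apart, with a 7.0-fold lower number from compound 2 to compound 4 (0.85 log units; beyond the scatter). So this position accepts two quite different kinds of group, and the one sharp penalty seen in these compounds comes from a single pair, whose large step can be tied to stereochemistry: the fact that compounds 1 and 2 differ only in the configuration as drawn.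

For the compounds shown here, it remains open whether the stereocentre of the new group matters as much as the one in the 1-phenylethyl group, since only one configuration of 1-(ethoxycarbonyl)-3-methylbutyl appears here. From the compounds shown here alone, it is also open which part of that group carries the result, a question that a carboxylic acid in place of the ethyl ester, or a plain isobutyl chain without the ester, would help to answer.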